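The compounds below may be only part of what the source reports. "The series", "measured", "known", "first", "only" and "open" are said of these compounds alone.

Working notes on the sulfonamide series.

Compound 1 `CCCCNc1ccc([N+](=O)[O-])cc1S(N)(=O)=O` gives 4.7% in an assay on HEK293 cells for inhibition of solute carrier family 12 member 2 (Homo sapiens), read by fluorescence, with a stated time of 30 min, tested at 100 uM; on this read-out lower numbers stand for a weaker effect and higher numbers for a stronger effect at the one concentration tested. Compound 2 `CCCCNc1ccc([N+](=O)[O-])cc1S(=O)(=O)NC` gives 13.3% in this assay; the change from compound 1 is methyl in place of hydrogen on a sulfonamide nitrogen, and the step is a number 8.6 percentage points higher from compound 1 to compound 2 (within the scatter). Compound 3 `CCCCNc1ccc(C(=O)O)cc1S(=O)(=O)NC` gives 6.2% in this assay; against compound 2 the step is a number 7.1 percentage points lower from compound 2 to compound 3 (within the scatter). The difference between the core of compound 3 and the core of compound 1 is not broken down here. Within the three measured compounds no value stands apart from the others beyond the usual spread of repeated measurements, so no compound can be called stronger or weaker than another on this read-out.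

Compound 4 `CCCCNc1ccc(C(=O)O)cc1S(=O)(=O)N(C)C` has not yet been measured in this assay. Against compound 3 the change is methyl in place of hydrogen on a sulfonamide nitrogen. This is the same kind of change as that from compound 1 to compound 2, but not the same: there the sulfonamide nitrogen carried only the sulfonyl sulfur as its other neighbour, whereas here its other neighbours are a saturated chain carbon and the sulfonyl sulfur. For the measured compounds named here, the only guide to its size is the earlier step, which stayed within the scatter, and a step of similar size, a number 4.8 percentage points higher from compound 3 to compound 4 (within the scatter), is expected here because compound 3 stands at 6.2%. Compound 4 is therefore expected to give about 11% in this assay, with a range from 0% to 28%.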

Compound 4, a percentage reported as inhibition, at one concentration (the size of the read-out at that concentration, not a potency): 15.6%
Estimate against measurement, compound 4: 4.6 percentage points below; measured number inside the range.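

In this assay the new step, methyl in place of hydrogen on a sulfonamide nitrogen, is a number 9.4 percentage points higher from compound 3 to compound 4 (within the scatter). Set beside the earlier step, it shows that the change reads alike on the core of compound 1 and the core of compound 3, with no difference that stands out from the scatter: the same change on two cores in this assay, a number 8.6 percentage points higher (within the scatter) from compound 1 to compound 2 and a number 9.4 percentage points higher (within the scatter) from compound 3 to compound 4, 0.8 percentage points apart, within the scatter of two such steps This does not show that the methyl has a real effect on either core, since each step taken alone lies within the scatter, and agreement on these two cores, where the nitrogen carries different neighbours before the change, gives no rule for any other core in the series.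

Open, as far as these compounds go, is whether a larger group on the sulfonamide nitrogen, such as ethyl, would give a step beyond the scatter, and what dimethylsulfamoyl would read on the core of compound 1. Also open, from the compounds shown here alone, is whether a longer chain on the amine nitrogen, or an amide or nitrile in place of the carboxy group, would lift the read-out clear of the spread seen so far.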